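The compounds below may be only part of what the source reports. "The series", "measured", "known", "first", "only" and "open" are said of these compounds alone.

Measured so far:
compound 1, `CC(C)(NC(=O)c1cccc2cc(-c3ccc(Cl)cc3)oc12)C(=O)O`: 1030 nM
compound 2, `CC(C)(NC(=O)c1cc(F)cc2cc(-c3ccc(Cl)cc3)oc12)c1nnn[nH]1`: 275 nM

In an assay on isolated protein for inhibition of endoplasmic reticulum aminopeptidase 1 (Homo sapiens), with stated times of 15 min and 20 min (on this read-out lower numbers stand for stronger inhibition and higher numbers for weaker inhibition), compound 1 gives 1030 nM, while compound 2 gives 275 nM. Of these two numbers compound 2 holds the lower one, and its gap to compound 1 lies beyond the scatter of repeated measurements. The two compounds differ from each other in more than one place, so no single step can be read between them.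

Compound 3, `CN(C(=O)c1cc(F)cc2cc(-c3ccc(Cl)cc3)oc12)C(C)(C)C(=O)O`, is still to be measured in this assay. It differs from compound 2 in one place: (1-carboxy-1-methylethyl)(methyl)amino in place of (1-(1H-tetrazol-5-yl)-1-methylethyl)amino on a carbonyl carbon. Compound 1, which also ends in a carboxylic acid rather than a tetrazole, gives 1030 nM, so compound 3 is expected to move toward weaker inhibition, with an estimated step of a 5.5-fold higher number from compound 2 to compound 3 (0.74 log units; beyond the scatter) that goes beyond the scatter. For compound 3 the estimate is 1500 nM, within a range from 500 nM to 5000 nM.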

Compound 3, half-maximal inhibitory concentration: 1970 nM
Compound 3: the middle estimate sits 1.3-fold (0.12 log units) below what was measured, within the range that was stated.
By their numbers in this assay, from the lowest: compound 2; then compounds 1 and 3 (each within the scatter of the next).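

In this assay, among these compounds, (1-carboxy-1-methylethyl)(methyl)amino in place of (1-(1H-tetrazol-5-yl)-1-methylethyl)amino on a carbonyl carbon gives a 7.2-fold higher number from compound 2 to compound 3 (0.86 log units; beyond the scatter), the first readable step, showing that inhibition responds to a change at this position. This single replacement carries two differences: a carboxylic acid replaces the tetrazole ring, and a methyl group replaces the amide hydrogen, so the step cannot be assigned to either one alone. No measured data on the compounds offer an account of this step.

Still open, as far as these compounds go, is how the step divides: a carboxylic acid with the amide hydrogen kept, or a tetrazole with the nitrogen methyl, on the core of compound 2 would separate the two differences. Also open, from the compounds shown here alone, is how an acyl sulfonamide would behave at this position.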